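The source may report more compounds than this note shows. Statements on the series, on what has been measured and on what is new or still open speak of the compounds shown alone.

Two members of the series have been run in a functional assay on HCT-116 cells (Homo sapiens) for inhibition, read by MTT assay, with a stated time of 48 h; on this read-out higher numbers stand for weaker inhibition and lower numbers for stronger inhibition. Compound 1 `CCCc1nnsc1CO/N=C/c1c(C)nn(C)c1Oc1ccc(F)cc1` gives 7060 nM in this assay. Compound 2 `CCc1nnsc1CO/N=C/c1c(C)nn(C)c1Cl` returns only the limit of this assay, > 50000 nM, so no number is known for it. That limit is the ceiling of what the assay reports (the limit of > 50000 nM in this assay, at which 1 of the 2 values shown sits), and one of the two values recorded sits there. Within the data shown here, compound 1 and compound 2 differ in more than one place, so together they show only that compound 1 yields a number while compound 2 does not.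

Compound 3 `CCCc1nnsc1CO/N=C/c1c(C)nn(C)c1Cl` has not been measured. Against compound 2 it carries methyl in place of hydrogen on a saturated chain carbon, two bonds along the chain from an aromatic carbon; cut one bond further out, the same change reads ethyl to propyl. Compound 3 thus shares the propyl chain with compound 1 and the chlorine with compound 2. Among the measured compounds shown here, no measured pair differs in this single place, so the step has no precedent. Because compound 2 stands at the limit > 50000 nM, the size of any step from it cannot be read off. The step of an at least 1.4-fold lower number from compound 2 to compound 3 (0.15 log units; that floor lies within the scatter) is expected to be small, not clearly beyond the scatter, with a modest gain the likelier direction. Compound 3 is accordingly estimated at 35000 nM, within 10000 nM to 100000 nM, and a real chance remains that this assay again returns only its limit.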

Compound 3, half-maximal inhibitory concentration: > 50000 nM
Compound 3 ended at the assay's limit (the forecaster's own chance of this, stated with the estimate: 45%); middle value at least 1.4-fold (0.15 log units) away from the limit.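

In this assay, the propyl chain is now held constant and chloro in place of 4-fluorophenoxy on an aromatic carbon can be read as a single change, giving an at least 7.0-fold higher number from compound 1 to compound 3 (0.85 log units; beyond the scatter). Among these compounds, compound 1 and compound 2 differed in more than one place, so this is the first step that isolates the group on that aromatic carbon, and with the propyl chain present, only the 4-fluorophenoxy compound gives a number rather than a limit. The ethyl to propyl change on the chloro compounds cannot be read, since compound 2 and compound 3 both stand at a limit and not at a number: the limit of > 50000 nM in this assay, at which 2 of the 3 values shown sit.

As far as these compounds go, the step from compound 1 to compound 3 has only a floor, so its full size remains open, as does whether the ethyl to propyl change has any effect when 4-fluorophenoxy replaces chloro. Also open, from the compounds shown here alone, is whether an amine such as morpholine or an unsubstituted phenoxy on that aromatic carbon would give a number in this assay, and whether a longer chain such as butyl would shift the value of compound 1.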